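The source may hold more compounds than are shown below. What is called first, only, known or untested is meant among the compounds shown, and "the series" means these compounds.

Compound 1 `CCCCCCOc1cc2c(c3c1C[C@@H]1[C@@H](C)CO[C@]1(C)O3)C[C@@H]1[C@@H](C)CO[C@]1(C)O2`: > 200000 nM, a limit of the assay
Compound 2 `C=C=CCOc1cc2c(c3c1C[C@@H]1[C@@H](C)CO[C@]1(C)O3)C[C@@H]1[C@@H](C)CO[C@]1(C)O2`: 11000 nM

Going by the values given here, in a functional assay on aorta (Rattus norvegicus, strain Sprague-Dawley) for inhibition (a higher number here means that more compound is needed for the effect, a lower number that less compound is needed), compound 2 gives 11000 nM, the only actual number so far. Compound 3 `CCCCOc1cc2c(c3c1C[C@@H]1[C@@H](C)CO[C@]1(C)O3)C[C@@H]1[C@@H](C)CO[C@]1(C)O2` differs from compound 2 in one group: propyl in place of propa-1,2-dien-1-yl on a saturated chain carbon bound to an oxygen on an aromatic ring. Among the compounds with values here, one measured step bears on this, at the same place: an at least 18-fold lower number from compound 1 to compound 2 (1.25 log units; beyond the scatter). Compound 3 carries a shorter chain than compound 1 but, like it, loses the double bonds, so part of that large step should reverse. The expected step is a 4.1-fold higher number from compound 2 to compound 3 (0.61 log units; beyond the scatter), towards a higher number. For compound 3 the estimated value is 45000 nM, with an expected range from 12000 nM to 200000 nM.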

Compound 3, half-maximal effective concentration: > 200000 nM
Compound 3 ended at the assay's limit; the forecaster's own chance of this, stated with the estimate: 30%; at least 4.4-fold (0.64 log units) between middle value and limit.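

In this assay, propyl in place of propa-1,2-dien-1-yl keeps the count of heavy atoms and removes only the double bonds, yet it gives an at least 18-fold higher number from compound 2 to compound 3 (1.25 log units; beyond the scatter). Among these compounds, then, chain size alone does not explain the measurable value of compound 2 at this position; the allene unit of double bonds goes with it. Compound 3 gives > 200000 nM, which is a limit of the assay.

As far as these compounds go, whether a chain with one double bond or a but-2-yn-1-yl chain with a triple bond would also give a measurable value stays open. The step between compound 1 and compound 3 cannot be read: the limit of > 200000 nM in this assay, at which 2 of the 3 values shown sit.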